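Putting a Substituent Back on the Phenyl Ring

This account rests on a few compounds, and the source may have more. Where it says the series, first, only, none or still open, it means among the compounds named here.

Measured in a functional assay on MCF7 cells (Homo sapiens) for antiproliferative activity, read by MTT assay, with a stated time of 72 h; on this read-out higher numbers stand for weaker inhibition and lower numbers for stronger inhibition:
compound 1 `COc1cc(-n2ncnc2-c2ccc(C)cc2)cc(OC)c1OC` gives 540 nM;
compound 2 `COc1ccc(-c2ncnn2-c2cc(OC)c(OC)c(OC)c2)cc1` gives 360 nM.
Compound 3 `COc1cc(-n2ncnc2-c2ccccc2)cc(OC)c1OC` gives > 10000 nM, which is a limit of the assay rather than a number.

Compound 3 therefore stands at the weak end of what has been seen: its value sits at the limit of > 10000 nM in this assay, at which 1 of the 3 values shown sits, and the two steps that lead to it, an at least 18-fold higher number from compound 1 to compound 3 (1.26 log units; beyond the scatter) and an at least 27-fold higher number from compound 2 to compound 3 (1.44 log units; beyond the scatter), are both large and beyond the scatter. Going by the values given here, the one step between the two numbered compounds, a 1.5-fold lower number from compound 1 to compound 2 (0.18 log units; within the scatter), is within the scatter, so methyl and methoxy cannot be told apart here.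

Compound 4 `COc1cc(-n2ncnc2-c2cccc(Cl)c2)cc(OC)c1OC` differs from compound 3 by chloro in place of hydrogen on an aromatic carbon. Among the compounds with values here, no measured step involves chloro, so the bearing is indirect. What the two large steps show is that removing a methyl or methoxy from the phenyl ring loses most of the activity; putting a chloro onto that ring runs the opposite way and may recover part of it, though how much is uncertain, and a limit again is possible. Compound 4 is expected to give about 3000 nM, in a range of 600 nM to 15000 nM. That expectation amounts to an at least 3.3-fold lower number from compound 3 to compound 4 (0.52 log units; beyond the scatter), a partial recovery rather than a return to the level of compound 1.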

Compound 4, half-maximal inhibitory concentration: > 10000 nM
Compound 4 gave a limit, no number; the forecaster's own chance of this, stated with the estimate: 35%; middle value at least 3.3-fold (0.52 log units) from the limit.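

In this assay compound 4 sits at the same limit of the assay as compound 3, and a limit is not a number: the limit of > 10000 nM in this assay, at which 2 of the 4 values shown sit. The step between these two compounds cannot be read, so any effect of chloro in place of hydrogen stays hidden. The new result does show that a group on this ring does not by itself bring activity back, since 3-chlorophenyl in place of 4-methylphenyl gives an at least 18-fold higher number from compound 1 to compound 4 (1.26 log units; beyond the scatter), and 3-chlorophenyl in place of 4-methoxyphenyl gives an at least 27-fold higher number from compound 2 to compound 4 (1.44 log units; beyond the scatter), both large steps that match the losses seen for plain phenyl.

Going by these compounds, these two steps change both the group and its place on the ring, so they cannot say whether the loss belongs to chloro itself or to where it sits, and how chloro would fare at the place of the methyl in compound 1 stays open. Also open, on these data alone, is whether a different group at that same place, such as an ethyl group or an amine, would keep activity at the level of compound 1 and compound 2.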